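The source may hold more compounds than are shown below. What is called first, only, known or untested is meant among the compounds shown, and "the series" means these compounds.

Three compounds share one core and differ only in the group on the amide-type nitrogen. Compound 1 `CC1=C(/C=C/C(C)=C/C=C/C(C)=C\C(=O)NCc2ccc(F)cc2)C(C)(C)CCC1n1ccnc1` gives 2450 nM in a functional assay on MDA-MB-468 cells (Homo sapiens) for inhibition, read by MTT assay; a lower number here means a stronger inhibitor of growth, a higher number a weaker inhibitor of growth; compound 2 `CC1=C(/C=C/C(C)=C/C=C/C(C)=C\C(=O)Nc2ccc(F)cc2)C(C)(C)CCC1n1ccnc1` gives 4570 nM; compound 3 `CC1=C(/C=C/C(C)=C/C=C/C(C)=C\C(=O)NCc2cccc(F)c2)C(C)(C)CCC1n1ccnc1` gives 3090 nM, the second highest of the three numbers. Every step among them stays within the scatter: a 1.9-fold higher number from compound 1 to compound 2 (0.27 log units; within the scatter), a 1.3-fold higher number from compound 1 to compound 3 (0.10 log units; within the scatter), a 1.5-fold lower number from compound 2 to compound 3 (0.17 log units; within the scatter). Compound 4 `CC1=C(/C=C/C(C)=C/C=C/C(C)=C\C(=O)Nc2ccccc2O)C(C)(C)CCC1n1ccnc1` carries 2-hydroxyphenyl in place of 3-fluorobenzyl on an amide-type nitrogen. Of the measured steps, a 1.9-fold higher number from compound 1 to compound 2 (0.27 log units; within the scatter) bears most on this; that step also exchanged a 4-fluorobenzyl for a 4-fluorophenyl on the amide-type nitrogen. Among the measured compounds shown here, the exchange of fluorine for a hydroxyl has no measured counterpart. The expected step for compound 4 is therefore a 1.3-fold higher number from compound 3 to compound 4 (0.11 log units; within the scatter), not beyond the scatter. Compound 4 is estimated at 4000 nM, between 1500 nM and 11000 nM.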

Compound 4, concentration for 50% growth inhibition: 3030 nM
For compound 4 the middle estimate is 1.3-fold (0.12 log units) above the measured one; measured number inside the range.
By their numbers in this assay, from the lowest: compounds 1, 4, 3 and 2 (each within the scatter of the next).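

In this assay, the 2-hydroxyphenyl group on the amide-type nitrogen stays level with all three fluorinated groups: a 1.0-fold lower number from compound 3 to compound 4 (0.01 log units; within the scatter), a 1.5-fold lower number from compound 2 to compound 4 (0.18 log units; within the scatter) and a 1.2-fold higher number from compound 1 to compound 4 (0.09 log units; within the scatter). The entering group brings a hydrogen-bond donor and a hydrogen-bond acceptor that 3-fluorobenzyl lacks, and even this change leaves the number within the scatter. Nothing available explains this result. Going by these compounds, whether an amine, a carboxylic acid or a longer chain on this nitrogen would carry the number beyond the scatter remains open.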